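This account rests on a few compounds, and the source may have more. Where it says the series, first, only, none or still open, it means among the compounds named here.

Three compounds of the series carry numbers in a functional assay on CCRF-CEM cells (Homo sapiens) for inhibition, read by sulforhodamine B assay, with a stated time of 48 h, tested at 10 uM; on this read-out lower numbers stand for less inhibition of growth and higher numbers for more inhibition of growth at the one concentration tested. Compound 1 `CC(=O)c1ccc(Nc2ccnc(SCC(=O)c3ccc(Br)cc3)n2)cc1` gives 30% in this assay. Compound 3 `CC(=O)c1ccc(Nc2ccnc(SCC(=O)c3ccc(Cl)cc3)n2)cc1` gives 29%; the step of a number 1 percentage points lower from compound 1 to compound 3 (within the scatter) lies within the scatter. For the measured compounds named here, compound 2 `CCOC(=O)c1ccc(Nc2ccnc(SCC(=O)c3ccc([N+](=O)[O-])cc3)n2)cc1` differs from compound 1 in two places, and in this assay compound 2 gives 49%; no single step connects it to compound 1, so its number is noted only as it stands. On these three numbers compound 1 stands second highest, with compound 3 nearest at a distance within the scatter and compound 2 furthest, beyond the scatter.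

Compound 4 `CC(=O)c1ccc(Nc2ccnc(SCC(=O)c3ccc(-c4ccccc4)cc3)n2)cc1` is not yet measured. It differs from compound 1 in one place: phenyl in place of bromo on an aromatic carbon. Going by the values given here, the only measured step of a related kind is the exchange of one halogen for another from compound 1 to compound 3, which stayed within the scatter. Among the compounds with values here, no measured step exchanges a halogen for a ring, so the weight of this change is not fixed by the data in hand, and the expectation rests on compound 1 alone with a wide range. The step from compound 1 to compound 4 in this assay is expected to be a number 2 percentage points higher from compound 1 to compound 4 (within the scatter). For compound 4 the estimate in this assay is 32%, ranging from 12% to 55%.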

Compound 4, percent growth inhibition at one concentration: 22%
The estimate for compound 4 lay 10 percentage points above the measured number; measured number inside the range.
By their numbers in this assay, from the lowest: compounds 4, 3 and 1 (each within the scatter of the next); then compound 2.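

In this assay the aromatic carbon para to a large group now carries a ring as well as a halogen: with phenyl in place of bromo the result is a number 8 percentage points lower from compound 1 to compound 4 (within the scatter), and with phenyl in place of chloro it is a number 7 percentage points lower from compound 3 to compound 4 (within the scatter). The earlier compounds shown here covered only an exchange of one halogen for another, whereas this change replaces a single bromine atom with six carbon atoms in a six-membered aromatic ring, and compound 4 still cannot be separated from compound 1 or compound 3 at the one concentration tested. No measurement on these compounds points to a cause for this result.

As far as these compounds go, it remains open whether the same position stays within the scatter with groups of another kind, such as an amine, a carboxylic acid or a longer alkyl chain in place of bromo or phenyl. Compound 2, at 49%, differs from compound 1 in two places, so its number cannot be assigned to either the nitro group or the ethyl ester alone.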